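Varying the aryl group on the sulfonyl sulfur

A few compounds are considered here, and "the series" means these few. Any claim that something is new, unique, unknown or untested is made for them only; others in the source may bear on it.

Compound 1: `CN(Cc1ccc(C2=NCCN2)cc1)C(=O)COCCN(C)S(=O)(=O)c1c(Cl)cccc1Cl`, 4.2 nM
Compound 2: `COc1ccc(S(=O)(=O)N(C)CCOCC(=O)N(C)Cc2ccc(C3=NCCN3)cc2)c(C)c1`, 5.5 nM
Compound 3: `CN(Cc1ccc(C2=NCCN2)cc1)C(=O)COCCN(C)S(=O)(=O)c1ccccc1C(F)(F)F`, 2.8 nM

In an assay on HEK293 cells for displacement of a labelled ligand from B1 bradykinin receptor (Homo sapiens), read by scintillation counting (on this read-out higher numbers stand for weaker inhibition and lower numbers for stronger inhibition), compound 3 gives 2.8 nM, the lowest of the three numbers, though its separation from the others is small: a 1.5-fold lower number from compound 1 to compound 3 (0.18 log units; within the scatter) and a 2.0-fold lower number from compound 2 to compound 3 (0.29 log units; within the scatter). Compound 1 and compound 2 are likewise close to each other, with a 1.3-fold higher number from compound 1 to compound 2 (0.12 log units; within the scatter). All three compounds share the same core and differ only in the group on the sulfonyl sulfur.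

Compound 4, `Cc1c(Cl)ccc(S(=O)(=O)N(C)CCOCC(=O)N(C)Cc2ccc(C3=NCCN3)cc2)c1Cl`, continues this series. Its change from compound 3 is 2,4-dichloro-3-methylphenyl in place of 2-(trifluoromethyl)phenyl on a sulfonyl sulfur. The three measured steps bear directly on it, since each also swaps one ring on the sulfonyl sulfur for another, and none of them moved the number beyond the scatter. The entering group shares its two chlorine atoms with the ring of compound 1, which in this assay gave 4.2 nM. Compound 4 is therefore expected to stay near the existing values, with a step of a 1.3-fold higher number from compound 3 to compound 4 (0.10 log units; within the scatter) that should be within the scatter. The estimate for compound 4 in this assay is 3.5 nM, with a range from 1.5 nM to 9 nM.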

Compound 4, inhibition constant: 2.1 nM
Compound 4: the middle estimate sits 1.7-fold (0.22 log units) above what was measured; low and high end bracket the measured number.
By their numbers in this assay, from the lowest: compounds 4, 3, 1 and 2 (each within the scatter of the next, the first and the last beyond it).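

In this assay, for the compounds shown here, the place on the sulfonyl sulfur also takes the 2,4-dichloro-3-methylphenyl group, which stays level with the two closest rings: the change gives a 1.3-fold lower number from compound 3 to compound 4 (0.12 log units; within the scatter) and a 2.0-fold lower number from compound 1 to compound 4 (0.30 log units; within the scatter) and so adds no separation from either compound. Going by these compounds alone, the new result also brings the first ring swap at this position to pass the scatter, a 2.6-fold lower number from compound 2 to compound 4 (0.42 log units; beyond the scatter) and a modest one, so the earlier picture of a position where every swap stayed within the scatter no longer holds for all pairs, although compound 3 and compound 1 still cannot be told apart from compound 4 or from each other. No measurement given here offers an explanation for this one wider gap.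

The compounds shown leave open whether the sulfonyl sulfur would keep numbers in this range with a ring that is not all carbon, such as pyridine, or with a saturated ring such as cyclohexyl in place of the aryl group. They also leave open what an amine or a carboxylic acid on the ring would do to the number.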